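From Methoxy to Cyano on the Aromatic Ring

The source may report more compounds than this note shows. Statements on the series, on what has been measured and on what is new or still open speak of the compounds shown alone.

In a physicochemical assay for lipophilicity, measured as octanol-water partition (a higher number here means a more lipophilic compound, a lower number a more polar compound), compound 1 (`O=C(NNc1ccnc2cc(Cl)ccc12)c1ccccc1/N=C/c1ccc(Cl)c(Cl)c1`) gives 6.22 and compound 2 (`Cc1ccc(/C=N/c2ccccc2C(=O)NNc2ccnc3cc(Cl)ccc23)cc1`) gives 5.31, while compound 3 (`COc1ccc(/C=N/c2ccccc2C(=O)NNc2ccnc3cc(Cl)ccc23)cc1`) gives 5 as the lowest of the three. Compound 4 (`N#Cc1ccc(/C=N/c2ccccc2C(=O)NNc2ccnc3cc(Cl)ccc23)cc1`) carries cyano in place of methoxy on an aromatic carbon. For the measured compounds named here, no measured compound here holds cyano, so the nearest guides are two swaps on the same ring, with a number 0.31 log units lower from compound 2 to compound 3 (beyond the scatter) as a modest step and a number 1.22 log units lower from compound 1 to compound 3 (beyond the scatter) as a large one. A modest downward change is therefore expected, with a number 0.40 log units lower from compound 3 to compound 4 (beyond the scatter) as the estimated step, although its direction remains uncertain. Compound 4 is expected to read 4.6 with a range from 4.1 to 5.1 in this measurement.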

Compound 4, partition coefficient: 4.83
Beside the measured number, compound 4's estimate is 0.23 log units below it; measured number inside the range.
By their numbers in this assay, from the lowest: compounds 4 and 3 (each within the scatter of the next); then compound 2; then compound 1.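

At this position on the ring, cyano and methoxy cannot be told apart in this assay (a number 0.17 log units lower from compound 3 to compound 4 (within the scatter)), even though they differ in the atoms they carry. Cyano does separate from methyl (a number 0.48 log units lower from compound 2 to compound 4 (beyond the scatter)), and the gap to the 3,4-dichlorophenyl compound is larger still (a number 1.39 log units lower from compound 1 to compound 4 (beyond the scatter)). Nothing available here explains these readings. On these data alone, whether an amine, a carboxylic acid or a longer chain at this position would fall near compound 4 or well away from it remains open.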